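The compounds below may be only part of what the source reports. "The series", "measured", "known", "first", "only" and "open" are said of these compounds alone.

Of the compounds shown here, two of this small set have been tested in a functional assay on PC-3 cells (Homo sapiens) for inhibition, read by MTT assay, with a stated time of 24 h; a lower number here means a stronger inhibitor, a higher number a weaker inhibitor. Compound 1 `[O-]/[N+](=C\c1cn(-c2ccc(C(F)(F)F)cc2)nn1)Cc1ccccc1` reached only a limit in this assay, > 100000 nM, so no number exists for it. For the measured compounds named here, compound 2 `CC(C)(C)/[N+]([O-])=C/c1cn(-c2ccc(F)cc2)nn1` gave 72100 nM in this assay, and this is the only actual number recorded; the other result is the limit of > 100000 nM in this assay, at which 1 of the 2 values shown sits, and tells nothing beyond that. Compound 3 `CC(C)(C)/[N+]([O-])=C/c1cn(-c2ccc(C(F)(F)F)cc2)nn1` differs from compound 2 in one respect: trifluoromethyl in place of fluoro on an aromatic carbon. Going by the values given here, no measured pair shows this change on its own, so its effect cannot be read from the data. Compound 3 is expected to be a weaker inhibitor than compound 2, with a step of a 1.5-fold higher number from compound 2 to compound 3 (0.18 log units; within the scatter) that goes beyond the usual scatter. The ground for this expectation is compound 1, which carries the trifluoromethyl group and gave only a limit, > 100000 nM. Compound 3 is therefore estimated at 110000 nM in this assay, within a range from 50000 nM to 250000 nM, and this assay may well report only a limit for it.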

Compound 3, half-maximal inhibitory concentration: 42000 nM
Compound 3: the middle estimate sits 2.6-fold (0.42 log units) above what was measured; the measured number lies below the stated range.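

In this assay, trifluoromethyl in place of fluoro on an aromatic carbon, para to a large group, gives a 1.7-fold lower number from compound 2 to compound 3 (0.23 log units; within the scatter), so with tert-butyl on the double-bonded nitrogen this change does not separate the two compounds. With trifluoromethyl held in place, tert-butyl in place of benzyl on the double-bonded nitrogen gives an at least 2.3-fold lower number from compound 1 to compound 3 (0.37 log units; beyond the scatter), so trifluoromethyl alone does not account for the result of compound 1. That step is only a minimum, since compound 1 stands at a limit of the assay and not at a number: the limit of > 100000 nM in this assay, at which 1 of the 3 values shown sits.

From the compounds shown here alone, what a nitrile or a methoxy group would do on that aromatic carbon stays open. Also open, going by these compounds, is how an isopropyl or a cyclohexyl group would compare with tert-butyl on the double-bonded nitrogen.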